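Aryl replacement on the anilino nitrogen: compounds 2 and 3

The source may hold more compounds than are shown below. What is called first, only, known or untested is meant among the compounds shown, and "the series" means these compounds.

Measured compounds:
compound 1, `Cc1cnc(Nc2ccc([N+](=O)[O-])cc2)nc1Nc1nc2ccccc2s1`: in a functional assay on MDA-MB-231 cells (Homo sapiens) for antiproliferative activity, read by MTT assay, with a stated time of 48 h (on this read-out higher numbers stand for weaker inhibition and lower numbers for stronger inhibition), compound 1 gives 22500 nM.
compound 2, `Cc1cnc(Nc2ccc(Cl)cc2)nc1Nc1nc2ccccc2s1`: in this assay compound 2 gives > 50000 nM, which is a limit of the assay rather than a number.

For the measured compounds named here, compound 2 thus stands at the edge of what this assay reports, as the limit of > 50000 nM in this assay, at which 1 of the 2 values shown sits, records; of the two values shown, only that of compound 1 is a number. Going by the values given here, the single measured step changes the aryl group on the same nitrogen: an at least 2.2-fold higher number from compound 1 to compound 2 (0.34 log units; beyond the scatter). Compound 3, `COc1cccc(Nc2ncc(C)c(Nc3nc4ccccc4s3)n2)c1`, differs from compound 2 in that (3-methoxyphenyl in place of 4-chlorophenyl on a nitrogen on an aromatic ring). The step of an at least 2.2-fold higher number from compound 1 to compound 2 (0.34 log units; beyond the scatter) is the only one that bears on this change, and it concerns a different substituent on that aryl ring; it shows the position can shift the number modestly, with both compounds weak. Among the compounds with values here, no measured pair compares methoxy with chloro. Compound 3 is therefore expected to stay near the limit, with the estimated step that the limit leaves unreadable from compound 2 to compound 3 not beyond the scatter. The estimate for compound 3 is 60000 nM, ranging from 20000 nM to 200000 nM, with a fair chance that only a limit is reported again.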

Compound 3, half-maximal inhibitory concentration: > 50000 nM
Compound 3: only a limit was reported (the forecaster's own chance of this, stated with the estimate: 60%); the middle value is on the limit's open side.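

In this assay compound 3 gives > 50000 nM, which is a limit of the assay and not a number. Exchanging 4-nitrophenyl for 3-methoxyphenyl on this nitrogen gives an at least 2.2-fold higher number from compound 1 to compound 3 (0.34 log units; beyond the scatter), so a second aryl replacement now moves the read-out in the same direction as the 4-chlorophenyl change did. The step between the two limit compounds cannot be read, which leaves 3-methoxyphenyl and 4-chlorophenyl unordered, and the limit is now the more common record in this small set: the limit of > 50000 nM in this assay, at which 2 of the 3 values shown sit.

As far as these compounds go, how far compound 2 and compound 3 lie past the limit remains unknown, and a single numerical value cannot show whether the nitro group itself matters or whether other aryl groups on this nitrogen could also give a number. From the compounds shown here alone, it also remains open whether an aryl ring carrying an amine or a carboxylic acid, or a longer alkyl chain in place of the aryl ring, would give a number in this assay.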